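This account rests on a few compounds, and the source may have more. Where it says the series, first, only, none or still open, it means among the compounds named here.

Measured in a functional assay on MCF7 cells (Homo sapiens) for antiproliferative activity, read by MTT assay, with a stated time of 48 h; on this read-out lower numbers stand for stronger inhibition and higher numbers for weaker inhibition:
- compound 1 (`COc1ccc(-c2nn(-c3ccccc3)cc2CNc2ccc(Br)cc2)cc1`): 7020 nM
- compound 2 (`COc1ccc(-c2nn(-c3ccccc3)cc2CNc2ccc(F)cc2)cc1`): 5980 nM
- compound 3 (`Cc1ccc(-c2nn(-c3ccccc3)cc2CNc2ccc(Cl)cc2)cc1`): 6020 nM

Compound 3 lies within the scatter of both compound 1 and compound 2, so the three values form one group. Compound 4 (`COc1ccc(-c2nn(-c3ccccc3)cc2CNc2ccc(Cl)cc2)cc1`) has methoxy in place of methyl on an aromatic carbon, para to a large group (methoxy in place of methyl on an aromatic carbon). Within the data shown here, no measured pair shows this change alone. Among the measured compounds shown here, the only measured step, fluoro in place of bromo on an aromatic carbon (a 1.2-fold lower number from compound 1 to compound 2 (0.07 log units; within the scatter)), stays within the scatter. Compound 1 and compound 2 already carry the 4-methoxyphenyl group, and compound 2 at 5980 nM still sits within the scatter of compound 3. No step beyond the scatter is therefore expected in this assay (estimated: a 1.0-fold higher number from compound 3 to compound 4 (0.02 log units; within the scatter)). Compound 4 is expected at 6300 nM (estimated range 3800 nM to 10500 nM).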

Compound 4, half-maximal inhibitory concentration: 6250 nM
The estimate for compound 4 lay 1.0-fold (0.00 log units) above the measured number, and the stated range covers the measured number.
By their numbers in this assay, from the lowest: compounds 2, 3, 4 and 1 (each within the scatter of the next).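

In this assay the change from 4-methylphenyl to 4-methoxyphenyl now has a measured pair of its own, and the step stays within the scatter (a 1.0-fold higher number from compound 3 to compound 4 (0.02 log units; within the scatter)). With chloro at the same place on the other aromatic ring, the halogen steps also stay within the scatter (a 1.0-fold higher number from compound 2 to compound 4 (0.02 log units; within the scatter) and a 1.1-fold lower number from compound 1 to compound 4 (0.05 log units; within the scatter)), so fluoro, chloro and bromo are not told apart there. Nothing available explains why these changes leave the number within the scatter. Still open, as far as these compounds go, is whether an amine or a carboxylic acid in place of the methoxy would give a step beyond the scatter in this assay.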